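Swapping Cyclohexyl for a Nitroaryl on an Aromatase Series

The source may report more compounds than this note shows. Statements on the series, on what has been measured and on what is new or still open speak of the compounds shown alone.

Compound 1, `O=C(Nc1ccc([N+](=O)[O-])cc1OCc1ccccc1)C1CCCCC1`, was tested in an assay on SK-BR-3 cells for inhibition of Aromatase (Homo sapiens); on this read-out higher numbers stand for weaker inhibition and lower numbers for stronger inhibition. Compound 1 gives only a limit of the assay, > 25000 nM, not a number. Compound 2, `O=C(Nc1ccc([N+](=O)[O-])cc1OCc1ccccc1)c1ccc(Cl)c([N+](=O)[O-])c1`, carries 4-chloro-3-nitrophenyl in place of cyclohexyl on a carbonyl carbon. In this assay compound 2 likewise gives only a limit, > 25000 nM. The step between them, a step that the two limits leave unreadable from compound 1 to compound 2, cannot be read because of the limit of > 25000 nM in this assay, at which 2 of the 3 values shown sit. Compound 3, `CN(c1ccc(NC(=O)C2CCCCC2)cc1OCc1ccccc1)S(C)(=O)=O`, rests on a different core; the difference between the two cores is not broken down here. In this assay compound 3 gives 250 nM. Compound 4, `CN(c1ccc(NC(=O)c2ccc(Cl)c([N+](=O)[O-])c2)cc1OCc1ccccc1)S(C)(=O)=O`, has not yet been measured and differs from compound 3 by 4-chloro-3-nitrophenyl in place of cyclohexyl on a carbonyl carbon. The surroundings of the place are identical in both pairs, so this is the same change, now made on a core that does yield a number. For the measured compounds named here, since the only earlier instance of the change has no readable size, no size can be carried over, and the expected step is a 2.0-fold higher number from compound 3 to compound 4 (0.30 log units; within the scatter), a cautious guess anchored on compound 3 at 250 nM. Compound 4 is estimated at 500 nM, within a wide band from 80 nM to 5000 nM.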

Compound 4, half-maximal inhibitory concentration: 690 nM
Compound 4: middle estimate off by 1.4-fold (0.14 log units), on the low side, within the range that was stated.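

In this assay, putting 4-chloro-3-nitrophenyl in place of cyclohexyl on the carbonyl carbon gives a 2.8-fold higher number from compound 3 to compound 4 (0.44 log units; beyond the scatter), so on this core the change modestly weakens inhibition and still leaves a measurable value. Compound 1 and compound 2 each give only a limit of the assay, not a number, and the same change on their core cannot be read because of this: the limit of > 25000 nM in this assay, at which 2 of the 4 values shown sit. The series therefore offers just one readable size for this change, which shows what it does on one core but cannot show whether that size carries over to the other.

The entering group brings an aromatic ring, a chlorine and a nitro group all at once, and the compounds shown do not separate what each part contributes to the step. On these data alone, whether a plain phenyl, or a cyclohexyl carrying an amine or a carboxylic acid, on the same carbonyl carbon would land nearer compound 3 or compound 4 remains open.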